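The source may report more compounds than this note shows. Statements on the series, on what has been measured and on what is new or still open speak of the compounds shown alone.

Measured so far:
- compound 1 `O=C([C@H]1CC2CCC1C2)N1CC(c2nc(-c3ccccc3)no2)C1` — 120 nM
- compound 2 `O=C([C@H]1CC2CCC1C2)N1CC(c2nc(-c3cccc(F)c3)no2)C1` — 72 nM

In an assay on HEK293 cells for positive allosteric modulation of metabotropic glutamate receptor 5 (Homo sapiens), read by FLIPR (a lower number here means that less compound is needed, a higher number that more compound is needed for the effect), compound 1 gives 120 nM and compound 2 gives 72 nM. Among the measured compounds shown here, the one step between them, a 1.7-fold lower number from compound 1 to compound 2 (0.22 log units; within the scatter), is fluoro in place of hydrogen on an aromatic carbon and stays within the scatter. Compound 2 therefore holds the lowest of the two numbers, but its gap to compound 1 is not one that can be read as a difference.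

Compound 3 `Cc1ccc(C(=O)N2CC(c3nc(-c4cccc(F)c4)no3)C2)cc1` has not yet been measured in this assay. The change from compound 2 to compound 3 is a group of 7 heavy atoms (7 carbon; one six-membered aromatic ring of carbon only) in place of a group of 7 heavy atoms (7 carbon; 2 five-membered non-aromatic rings of carbon only), on a carbonyl carbon. For the measured compounds named here, no measured step bears on this change: the only step in hand alters the aromatic ring on the other side of the shared core and leaves the carbonyl side untouched, so there is nothing here that tells the size or direction of the step in this assay for an exchange at the carbonyl carbon.

For compound 3 the estimate in this assay is therefore anchored on compound 2 with a wide range, 150 nM (40 nM to 600 nM). The expected step from compound 2 to compound 3 is a 2.1-fold higher number from compound 2 to compound 3 (0.32 log units; beyond the scatter), and no direction beyond the scatter is expected.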

Compound 3, half-maximal effective concentration: 6800 nM
The estimate for compound 3 lay 45-fold (1.66 log units) below the measured number, outside the stated range (above it).
By their numbers in this assay, from the lowest: compounds 2 and 1 (each within the scatter of the next); then compound 3.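

Working note on the carbonyl carbon: in this assay, exchanging the group on this carbon gives a 94-fold higher number from compound 2 to compound 3 (1.98 log units; beyond the scatter) and is the first step in the series beyond the scatter, whereas a 1.7-fold lower number from compound 1 to compound 2 (0.22 log units; within the scatter) on the aromatic ring on the other side of the shared core stays within it. The large step occurs with the listed counts unchanged: both groups have 7 heavy atoms, all carbon, with 0 hydrogen-bond donors, 0 hydrogen-bond acceptors and no net charge, so these counts alone do not account for the difference between compound 2 and compound 3. No measurement at hand offers an explanation for this step.

This single exchange changes several things at once, replacing 2 five-membered non-aromatic rings and 1 defined stereocentre with 4-methylphenyl, so the contribution of each remains unresolved. Also open, going by these compounds, is whether a tert-butyl group, a longer alkyl chain or an unsubstituted phenyl on this carbonyl carbon would give a number close to that of compound 2 or of compound 3.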